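Methoxy to hydroxy on two stilbene-like cores

The compounds below may be only part of what the source reports. "The series", "measured", "known", "first", "only" and "open" are said of these compounds alone.

Measured compounds:
compound 1, `Cc1cc(/C=C/c2ccc(O)cc2)[nH]n1`: 38800 nM
compound 2, `COc1ccc(/C=C/c2cc(C)n[nH]2)cc1`: 9400 nM
compound 3, `COc1ccc(/C=C/C(=O)CC(C)=O)cc1`: 11900 nM

All three were run in a functional assay on HCT-116 cells (Homo sapiens) for cytotoxicity, read by MTT assay, with a stated time of 72 h; a lower number here means a stronger inhibitor, a higher number a weaker inhibitor. Compound 2 and compound 3 share a methoxy-bearing aryl group but differ in the rest of the molecule; the difference between the two cores is not broken down here, and their values lie within the scatter of one another. Compound 4, `CC(=O)CC(=O)/C=C/c1ccc(O)cc1`, has not yet been measured. It differs from compound 3 by hydrogen in place of methyl on an oxygen on an aromatic ring, the same change that separates compound 2 from compound 1, (hydrogen in place of methyl on an oxygen on an aromatic ring), which gave a 4.1-fold higher number from compound 2 to compound 1 (0.62 log units; beyond the scatter). On the core of compound 3 the same change is expected to give a step of similar size, a 3.8-fold higher number from compound 3 to compound 4 (0.58 log units; beyond the scatter), resting only on that one measured pair. For compound 4 the number in this assay is expected near 45000 nM, between 15000 nM and 130000 nM.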

Compound 4, half-maximal inhibitory concentration: 36500 nM
Compound 4: middle estimate off by 1.2-fold (0.09 log units), on the high side, within the range that was stated.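

Replacing methoxy with hydroxy on a second core gives a 3.1-fold higher number from compound 3 to compound 4 (0.49 log units; beyond the scatter) in this assay and so repeats the direction seen on the first core. The two steps cannot be told apart in size, so within this series the change carries from one core to the other: the same change on two cores in this assay, a 4.1-fold higher number (0.62 log units; beyond the scatter) from compound 2 to compound 1 and a 3.1-fold higher number (0.49 log units; beyond the scatter) from compound 3 to compound 4, 1.3-fold (0.13 log units) apart, within the scatter of two such steps. Going by these compounds alone, this rests on only two matched pairs in a single cell assay, and it shows neither why hydroxy gives the higher numbers nor whether the step would hold on any further core.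

Open, on these data alone, is how other groups on that oxygen, such as ethyl or a longer chain, would compare with methoxy and hydroxy. Also open, as far as these compounds go, is whether an amine or a fluorine in place of that oxygen would follow the same trend.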